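Swapping a Phenyl for an Isobutoxy Group on Compound 3

A few compounds are considered here, and "the series" means these few. Any claim that something is new, unique, unknown or untested is made for them only; others in the source may bear on it.

Compound 1 `CC(C)N(Cc1cccc(OCCCCCC(=O)O)c1)C(=O)c1ccccc1` gives > 26000 nM in an ADME assay on BJ cells (Homo sapiens) for cytotoxicity, read by CellTiter-Glo and resazurin assay, with a stated time of 72 h; on this read-out lower numbers stand for an effect already at smaller amounts and higher numbers for an effect only at larger amounts of compound. Compound 2 `CC(C)N(Cc1cccc(OCCCCCC(=O)O)c1)C(=O)c1ccc(-c2cccc3ccccc23)cc1` gives < 1.3 nM. Compound 3 `CC(C)N(Cc1cccc(OCCCCCC(=O)O)c1)C(=O)c1ccc(-c2cccc(-c3ccccc3)c2)cc1` gives > 26000 nM.

Two of these three results are limits of this assay rather than numbers. For compound 3 the value > 26000 nM is such a limit, so its exact position is unknown; it shares that limit with one other compound, as shown by the limit of > 26000 nM in this assay, at which 2 of the 3 values shown sit. Compound 2 sits at the opposite limit, (the limit of < 1.3 nM in this assay, at which 1 of the 3 values shown sits).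

Compound 4 `CC(C)COc1cccc(-c2ccc(C(=O)N(Cc3cccc(OCCCCCC(=O)O)c3)C(C)C)cc2)c1` differs from compound 3 by isobutoxy in place of phenyl on an aromatic carbon. For the measured compounds named here, none of the measured steps involves an isobutoxy group. The steps that were measured are an at least 20000-fold lower number from compound 1 to compound 2 (4.30 log units; beyond the scatter) and an at least 20000-fold higher number from compound 2 to compound 3 (4.30 log units; beyond the scatter), both large, while a step that the two limits leave unreadable from compound 1 to compound 3 stays unreadable. So the known steps show only that a change on this aromatic carbon can move the number very far in either direction.

Because compound 3 gives > 26000 nM, a limit, the step to compound 4 cannot be read sharply either way. Compound 4 is therefore expected to stay near that limit, with an estimated value of 15000 nM and a plausible range from 500 nM to 30000 nM. That estimate means an expected step of an at least 1.7-fold lower number from compound 3 to compound 4 (0.23 log units; that floor lies within the scatter).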

Compound 4, half-maximal effective concentration: > 26000 nM
Compound 4 gave a limit, no number (the forecaster's own chance of this, stated with the estimate: 55%); at least 1.7-fold (0.23 log units) between middle value and limit.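

The outer phenyl of compound 3 can give way to isobutoxy, which has no ring and brings an oxygen, and the result still stays at the high end of this assay. With 3-(isobutoxy)phenyl in place of naphthalen-1-yl there is an at least 20000-fold higher number from compound 2 to compound 4 (4.30 log units; beyond the scatter), so compound 2 remains the only one of these compounds at the low end, and two quite different groups at this place on the 3-substituted phenyl both leave the number at the high end. The steps from compound 3 to compound 4 and from compound 1 to compound 4 cannot be read, because both ends of each step sit at one and the same limit: the limit of > 26000 nM in this assay, at which 3 of the 4 values shown sit.

As far as these compounds go, how far compound 3 and compound 4 really lie beyond that limit stays unknown, so any difference between phenyl and isobutoxy here remains hidden. Also open, from the compounds shown here alone, is whether a methoxy group or an amine at this place would bring the number down toward that of compound 2, or whether only a fused ring such as naphthalen-1-yl does so.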